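Series notes: chloro step onto the methyl analogue

A few compounds are considered here, and "the series" means these few. Any claim that something is new, unique, unknown or untested is made for them only; others in the source may bear on it.

Measured compounds:
compound 1 `O=C(CCc1nnc(-c2ccccc2)o1)c1ccccc1` gives 18.7%
compound 2 `O=C(CCc1nnc(-c2ccccc2Cl)o1)c1ccccc1` gives 26.9%
compound 3 `Cc1ccc(C(=O)CCc2nnc(-c3ccccc3)o2)cc1` gives 33.3%

In a functional assay on the whole organism (strain Wistar) for inhibition, with Rattus norvegicus as the target, with stated times of 30 min and 2 h, at a dose of 20 mg/kg by the oral route (a lower number here means less inhibition, a higher number more inhibition at the dose given (going by the name of the read-out)), compound 3 stands highest of the three numbers shown. Compound 2 lies within the scatter of it; compound 1 lies beyond it, the step being a number 14.6 percentage points higher from compound 1 to compound 3 (beyond the scatter).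

Compound 4 `Cc1ccc(C(=O)CCc2nnc(-c3ccccc3Cl)o2)cc1` differs from compound 3 by chloro in place of hydrogen on an aromatic carbon. Going by the values given here, the only measured step of this kind is a number 8.2 percentage points higher from compound 1 to compound 2 (within the scatter), which stayed within the scatter. A step of about that size is therefore expected, upward in direction but not certain to clear the scatter. For compound 4 the expected step in this assay is a number 7.7 percentage points higher from compound 3 to compound 4 (within the scatter). Compound 4 is expected to give 41%, with the range 29% to 53%.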

Compound 4, a percentage reported as inhibition, in the whole organism at one dose (the size of the read-out at that dose, not a potency): 36.2%
Estimate against measurement, compound 4: 4.8 percentage points above, within the range that was stated.
By their numbers in this assay, from the lowest: compounds 1, 2, 3 and 4 (each within the scatter of the next, the first and the last beyond it).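

In this assay, chloro in place of hydrogen ortho to a large group now has a second reading, a number 2.9 percentage points higher from compound 3 to compound 4 (within the scatter), so on neither core does this change clear the scatter, and the two readings agree: the same change on two cores in this assay, a number 8.2 percentage points higher (within the scatter) from compound 1 to compound 2 and a number 2.9 percentage points higher (within the scatter) from compound 3 to compound 4, 5.3 percentage points apart, within the scatter of two such steps. The methyl change, read on the chlorinated core, gives a number 9.3 percentage points higher from compound 2 to compound 4 (within the scatter), which stays within the scatter, unlike the step on the core of compound 1, though the two steps cannot be told apart: the same change on two cores in this assay, a number 14.6 percentage points higher (beyond the scatter) from compound 1 to compound 3 and a number 9.3 percentage points higher (within the scatter) from compound 2 to compound 4, 5.3 percentage points apart, within the scatter of two such steps.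

From the compounds shown here alone, whether a methoxy group or an amine in place of the chloro would give a step beyond the scatter stays open. Going by these compounds, the effect of a longer chain in the shared core also stays open.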